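Stretching the Alkoxy Chain Further

The source may hold more compounds than are shown below. What is called first, only, known or untested is meant among the compounds shown, and "the series" means these compounds.

Compound 1 `CCCCCOc1ccc(-c2c(C)[nH]c(=O)n2C)cc1` and compound 2 `CCCCCCCCCCCOc1ccc(-c2c(C)[nH]c(=O)n2C)cc1` share one core and differ only by hexyl in place of hydrogen on a saturated chain carbon, five bonds along the chain from an oxygen on an aromatic ring. In a functional assay on brain (Rattus norvegicus, strain Wistar) for inhibition (on this read-out lower numbers stand for stronger inhibition and higher numbers for weaker inhibition), compound 1 gives 4500 nM, while compound 2 gives 9700 nM; the step is a 2.2-fold higher number from compound 1 to compound 2 (0.33 log units; beyond the scatter). Compound 3 `CCCCCCCCCCCCOc1ccc(-c2c(C)[nH]c(=O)n2C2CCCCC2)cc1` carries a different core, and the difference between the two cores is not broken down here. In this assay compound 3 gives 52400 nM, the highest of the three numbers. Compound 4 `CCCCCCCCCCCCCCCCCCOc1ccc(-c2c(C)[nH]c(=O)n2C2CCCCC2)cc1` is built from compound 3 by hexyl in place of hydrogen on a saturated chain carbon, ten or more bonds along the chain from an oxygen on an aromatic ring. This is the same kind of change as before, though the place along the chain differs, as the two differences just described show. Compound 4 is therefore expected to give about 110000 nM, somewhere between 40000 nM and 300000 nM. That estimate means an expected step of a 2.1-fold higher number from compound 3 to compound 4 (0.32 log units; beyond the scatter), chosen because of a 2.2-fold higher number from compound 1 to compound 2 (0.33 log units; beyond the scatter).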

Compound 4, half-maximal inhibitory concentration: > 100000 nM
Compound 4 was reported as a limit (the forecaster's own chance of this, stated with the estimate: 40%); the middle value is on the limit's open side.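

In this assay compound 4 gives > 100000 nM, which is a limit of the assay and not a number. Adding hexyl to the chain on this second core gives an at least 1.9-fold higher number from compound 3 to compound 4 (0.28 log units; that floor lies within the scatter), so the result fits the rise seen on the core of compound 1 but does not by itself establish a rise. The size of the change on the two cores cannot be compared, so carrying it from one core to the other is neither confirmed nor ruled out: the same change on two cores in this assay, a 2.2-fold higher number (0.33 log units; beyond the scatter) from compound 1 to compound 2 and an at least 1.9-fold higher number (0.28 log units; that floor lies within the scatter) from compound 3 to compound 4; the limit leaves it open whether they differ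

The compounds shown leave open where the true value of compound 4 lies. They also leave open whether a chain ending in a carboxylic acid or an amine would behave like these plain chains on either core.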